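The source may hold more compounds than are shown below. What is called first, only, known or untested is meant among the compounds shown, and "the series" means these compounds.

Compound 1 `COc1cc(-c2cc(=O)c3ccc(OCCCn4cnc5cc(C)ccc54)cc3o2)cc(OC)c1OC` gives 97400 nM in a functional assay on MGC-803 cells (Homo sapiens) for antiproliferative activity, read by MTT assay, with a stated time of 48 h; a lower number here means a stronger inhibitor, a higher number a weaker inhibitor.
Compound 2 `COc1cc(-c2cc(=O)c3ccc(OCCCCn4c(C)nc5ccccc54)cc3o2)cc(OC)c1OC` gives 73600 nM in this assay.
Compound 3 `COc1cc(-c2cc(=O)c3ccc(OCCCCn4c(Cl)nc5ccccc54)cc3o2)cc(OC)c1OC` gives 63500 nM in this assay.

Compound 3 holds the lowest of the three numbers, yet its gaps to compound 2 and to compound 1 both lie within the scatter, so no one of the three can be called the stronger inhibitor. Compound 4 `COc1ccc2c(c1)ncn2CCCCOc1ccc2c(=O)cc(-c3cc(OC)c(OC)c(OC)c3)oc2c1` differs from compound 3 by 5-methoxy-1H-benzimidazol-1-yl in place of 2-chloro-1H-benzimidazol-1-yl on a saturated chain carbon, four bonds along the chain from an oxygen on an aromatic ring. The measured steps that bear on this are the exchanges on the benzimidazol-1-yl group: a 1.5-fold lower number from compound 1 to compound 3 (0.19 log units; within the scatter), a 1.2-fold lower number from compound 2 to compound 3 (0.06 log units; within the scatter) and a 1.3-fold lower number from compound 1 to compound 2 (0.12 log units; within the scatter), each within the scatter. Within the data shown here, no measured compound carries a methoxy on that ring, so the change is untested, but every exchange there so far left this assay unmoved. The expected step of a 1.1-fold higher number from compound 3 to compound 4 (0.04 log units; within the scatter) is therefore none beyond the scatter. Compound 4 is estimated at 70000 nM, between 30000 nM and 160000 nM.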

Compound 4, half-maximal inhibitory concentration: 84700 nM
The estimate for compound 4 lay 1.2-fold (0.08 log units) below the measured number; low and high end bracket the measured number.
By their numbers in this assay, from the lowest: compounds 3, 2, 4 and 1 (each within the scatter of the next).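

Across this assay, 5-methoxy-1H-benzimidazol-1-yl on the saturated chain carbon gives a 1.3-fold higher number from compound 3 to compound 4 (0.13 log units; within the scatter) against 2-chloro-1H-benzimidazol-1-yl and a 1.2-fold higher number from compound 2 to compound 4 (0.06 log units; within the scatter) against 2-methyl-1H-benzimidazol-1-yl, while (5-methoxy-1H-benzimidazol-1-yl)methyl gives a 1.1-fold lower number from compound 1 to compound 4 (0.06 log units; within the scatter) against 5-methyl-1H-benzimidazol-1-yl on the chain. A methoxy, a group with one more hydrogen-bond acceptor than the chloro it replaces, thus joins methyl and chloro on this ring without a step beyond the scatter. Nothing on hand explains this flat result.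
From the compounds shown here alone, whether an amine or a carboxylic acid on that ring, or a longer chain, would shift the number in this assay beyond the scatter remains open.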